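From methyl to isobutyl: a step not yet measured

This account rests on a few compounds, and the source may have more. Where it says the series, first, only, none or still open, it means among the compounds named here.

Values from a functional assay on DU-145 cells (Homo sapiens) for cytotoxicity, read by MTT assay (a lower number here means a stronger inhibitor, a higher number a weaker inhibitor), stand as follows
- Compound 1 `C[C@H](NC(=S)Nc1cc(C(F)(F)F)cc(C(F)(F)F)c1)c1nc2ccccc2[nH]1` gives 154000 nM 
- Compound 2 `CC(C)C[C@H](NC(=S)Nc1ccccc1)c1nc2ccccc2[nH]1` gives 28900 nM 

Compound 1 has the higher number of the two, which makes it the weaker inhibitor, and its gap to compound 2 lies beyond the scatter. Compound 3 `CC(C)C[C@H](NC(=S)Nc1cc(C(F)(F)F)cc(C(F)(F)F)c1)c1nc2ccccc2[nH]1` awaits measurement in this assay and departs from compound 1 in one place isopropyl in place of hydrogen on a saturated chain carbon, two bonds along the chain from an amide-type nitrogen and an aromatic carbon with isopropyl in place of hydrogen on a saturated chain carbon, two bonds along the chain from an amide-type nitrogen and an aromatic carbon. Read one bond further out, this is methyl to isobutyl. Compound 2 also carries the isobutyl chain and gives 28900 nM as its value, although it differs from compound 1 elsewhere too, so this evidence is thin. A move beyond the scatter towards a lower number is expected, with a 4.4-fold lower number from compound 1 to compound 3 (0.64 log units; beyond the scatter) as the estimated step. For compound 3 the estimate is 35000 nM with a range from 10000 nM to 110000 nM as the expected span.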

Compound 3, half-maximal inhibitory concentration: 17200 nM
Compound 3: middle estimate off by 2.0-fold (0.31 log units), on the high side; the measured number falls inside the stated range.
By their numbers in this assay, from the lowest: compounds 3 and 2 (each within the scatter of the next); then compound 1.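

In this assay the change from methyl to isobutyl, taken alone, brings a 9.0-fold lower number from compound 1 to compound 3 (0.95 log units; beyond the scatter) on a saturated chain carbon, two bonds along the chain from an amide-type nitrogen and an aromatic carbon. This isolates the contribution of the change at this position, which the earlier pair could not do, since those two compounds also differ elsewhere. Nothing at hand accounts for the size of this step.

Going by these compounds, whether an intermediate ethyl group, a longer chain such as n-hexyl, or a chain bearing an amine or a carboxylic acid would lower the number further remains open. On these data alone, the step also rests on a single pair, so it is unknown whether it would recur with groups other than trifluoromethyl on the aromatic ring.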